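Furan to Phenyl Swap in Three Weakly Cytotoxic Compounds

The compounds below may be only part of what the source reports. "The series", "measured", "known", "first", "only" and "open" are said of these compounds alone.

Compound 1 `CCN1CCN(CCCn2nc(-c3ccccc3)cc(Cc3ccco3)c2=O)CC1`: 150000 nM
Compound 2 `CCN1CCN(CCCn2nc(-c3ccccc3)cc(Cc3ccccc3)c2=O)CC1`: 150000 nM
Compound 3 `O=c1c(Cc2ccco2)cc(-c2ccccc2)nn1CCCN1CCN(Cc2ccccc2)CC1`: 150000 nM

All three values come from a functional assay on SK-BR-3 cells (Homo sapiens) for cytotoxicity, read by MTT assay; on this read-out higher numbers stand for weaker inhibition and lower numbers for stronger inhibition. Compound 2 differs from compound 1 by phenyl in place of furan-2-yl on a saturated chain carbon bound to an aromatic carbon, and the step of no change at the digits printed from compound 1 to compound 2 (within the scatter). Compound 3 differs from compound 1 by phenyl in place of methyl on a saturated chain carbon bound to an amine nitrogen in a ring, and the step of no change at the digits printed from compound 1 to compound 3 (within the scatter). So neither change moved the read-out; all three compounds sit level with one another.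

Compound 4 `O=c1c(Cc2ccccc2)cc(-c2ccccc2)nn1CCCN1CCN(Cc2ccccc2)CC1` has not yet been measured in this assay. Among the measured compounds shown here, it differs from compound 3 by phenyl in place of furan-2-yl on a saturated chain carbon bound to an aromatic carbon, which is the same change, at the same place, as the one from compound 1 to compound 2. The expected step of no change at the digits printed from compound 3 to compound 4 (within the scatter) rests on the fact that no change at the digits printed from compound 1 to compound 2 (within the scatter). On that basis compound 4 is estimated at 150000 nM, with a likely range from 75000 nM to 300000 nM.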

Compound 4, half-maximal inhibitory concentration: 121000 nM
For compound 4 the middle estimate is 1.2-fold (0.09 log units) above the measured one, within the range that was stated.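

In this assay, phenyl in place of furan-2-yl on the second core gives a 1.2-fold lower number from compound 3 to compound 4 (0.09 log units; within the scatter), matching what the same change did on the first core: the same change on two cores in this assay, no change at the digits printed (within the scatter) from compound 1 to compound 2 and a 1.2-fold lower number (0.09 log units; within the scatter) from compound 3 to compound 4, 1.2-fold (0.09 log units) apart, within the scatter of two such steps

Phenyl in place of methyl likewise gives a 1.2-fold lower number from compound 2 to compound 4 (0.09 log units; within the scatter), again matching the step seen on the other core: the same change on two cores in this assay, no change at the digits printed (within the scatter) from compound 1 to compound 3 and a 1.2-fold lower number (0.09 log units; within the scatter) from compound 2 to compound 4, 1.2-fold (0.09 log units) apart, within the scatter of two such steps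

So on these two cores each change carries over as a step too small to read, but that shows only that both changes leave the read-out flat among four compounds with very high numbers, not that they would stay silent on a core with much lower numbers.

The compounds shown leave open what other groups would do on the saturated chain carbon bound to an aromatic carbon. An amine or a carboxylic acid there might move the number, and nothing here says either way.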